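A few compounds are considered here, and "the series" means these few. Any claim that something is new, unique, unknown or untested is made for them only; others in the source may bear on it.

The shared core of this series appears in compound 1 `O=C(O)Cn1c(=O)c(Oc2cc(O)cc(O)c2)nc2ccccc21` and compound 2 `O=C(O)Cn1c(=O)c(Oc2cc(O)cc(O)c2)nc2ccc(Cl)cc21`, which differ only by chloro in place of hydrogen on an aromatic carbon. In a physicochemical assay, read by spectrophotometry, with a stated time of 240 min, tested at 100 uM (on this read-out higher numbers stand for a stronger effect at the one concentration tested and lower numbers for a weaker effect), compound 1 gives 67.4%, and in this assay compound 2 gives 91.3%. That step, a number 23.9 percentage points higher from compound 1 to compound 2 (beyond the scatter), is the only measured one so far, and it leaves compound 2 as the higher of the two numbers in this assay, with compound 1 as its nearest neighbour.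

Compound 3 `O=C(O)Cn1c(=O)c(Oc2cc(O)cc(O)c2)nc2ccc(F)cc21` has not yet been measured. It differs from compound 2 as follows: fluoro in place of chloro on an aromatic carbon. Among the measured compounds shown here, no measured step shows a change of one halogen for another, so the only guide is that the halogen-bearing compound 2 stands well above the hydrogen-bearing compound 1 by a number 23.9 percentage points higher from compound 1 to compound 2 (beyond the scatter). Since compound 3 keeps a halogen at that place, a reading between the two measured numbers is expected, leaning toward compound 2. Compound 3 is therefore estimated in this assay at 80%, with a range from 62% to 94%, which would mean a step of a number 11.3 percentage points lower from compound 2 to compound 3 (beyond the scatter).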

Compound 3, a percentage reported as activity, at one concentration (the size of the read-out at that concentration, not a potency): 38.2%
Beside the measured number, compound 3's estimate is 41.8 percentage points above it; measured number outside the range, below it.
By their numbers in this assay, from the lowest: compound 3; then compound 1; then compound 2.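

In this assay, the place on the aromatic ring that carries the halogen turns out to be sensitive to which halogen stands there, since fluoro in place of chloro gives a number 53.1 percentage points lower from compound 2 to compound 3 (beyond the scatter) and so removes far more than the gain seen earlier. Having a halogen at this place is thus not enough for a higher reading: chloro in place of hydrogen gave a number 23.9 percentage points higher from compound 1 to compound 2 (beyond the scatter) while fluoro in place of hydrogen gives a number 29.2 percentage points lower from compound 1 to compound 3 (beyond the scatter), so the two halogens move the number in opposite directions from the unsubstituted compound 1. Nothing available here accounts for this split between two single-atom groups.

On these data alone, the order of fluoro, then hydrogen, then chloro rests on these three compounds at this one place, so it remains open where bromo, methyl or methoxy at the same place would fall. As far as these compounds go, it also remains open whether chloro and fluoro would differ as sharply elsewhere on the shared core, or whether the gap would hold with an amide in place of the carboxylic acid.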